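Swapping tert-Butyl for Amino: Expected Effect on Cytotoxicity

A few compounds are considered here, and "the series" means these few. Any claim that something is new, unique, unknown or untested is made for them only; others in the source may bear on it.

Measured so far in an ADME assay on HEK293 cells (Homo sapiens) for cytotoxicity, with a stated time of 72 h; on this read-out lower numbers stand for an effect already at smaller amounts and higher numbers for an effect only at larger amounts of compound:
compound 1 `Cc1cc(NC(=O)Nc2ccc(C(C)(C)C)cc2)c2ccccc2n1`: > 25000 nM.
compound 2 `COc1ccc(NC(=O)Nc2cc(C)nc3ccccc23)cc1Cl`: 26000 nM.
compound 3 `COC(=O)c1cccc(NC(=O)Nc2cc(C)nc3ccccc23)c1`: 26000 nM.
All three compounds share the same core.

For compound 1 the value > 25000 nM is a limit of this assay rather than a number, so compound 1 stands at the limit of > 25000 nM in this assay, at which 1 of the 3 values shown sits. Compound 2 gives 26000 nM and compound 3 gives 26000 nM; these two values lie within the usual scatter of each other.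

Compound 4 `Cc1cc(NC(=O)Nc2ccc(N)cc2)c2ccccc2n1` differs from compound 1 by amino in place of tert-butyl on an aromatic carbon. Among the compounds with values here, no pair of measured compounds shows this kind of change, so no measured step can guide the expectation. The step from compound 1 to compound 4 is expected to be a number no higher from compound 1 to compound 4 (the limit leaves the size open), none beyond the scatter. Compound 4 is estimated at 25000 nM, with a range from 10000 nM to 50000 nM.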

Compound 4, half-maximal effective concentration: > 25000 nM
Compound 4: only a limit was reported; the forecaster's own chance of this, stated with the estimate: 60%; the middle value sits exactly at the limit.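

In this assay, within the data shown here, compound 1 and compound 4 both give only a limit, so no step between them can be read. From the compounds shown here alone, whether amino in place of tert-butyl changes this read-out at all stays open.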